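A few compounds are considered here, and "the series" means these few. Any claim that something is new, unique, unknown or untested is made for them only; others in the source may bear on it.

Among the measured compounds shown here, compound 2 `Nc1nn2c(O)cc(CCl)nc2c1[N+](=O)[O-]` is one of two compounds measured so far in a functional assay on L929 cells (Mus musculus) for inhibition; a lower number here means a stronger inhibitor of growth, a higher number a weaker inhibitor of growth. In this assay compound 2 reaches only the limit of the assay, > 50 ug/mL, not a number. Compound 1 `Nc1nn2c(O)cc(-c3ccccc3F)nc2c1[N+](=O)[O-]` likewise gives only a limit in this assay, > 50 ug/mL. Both sit at the same boundary, (the limit of > 50 ug/mL in this assay, at which 2 of the 2 values shown sit), so the step that the two limits leave unreadable from compound 1 to compound 2 cannot be read. Compound 3 `NNCc1cc(O)n2nc(N)c([N+](=O)[O-])c2n1`, not yet measured, differs from compound 2 by aminoamino in place of chloro on a saturated chain carbon bound to an aromatic carbon. For the measured compounds named here, the only measured step, unreadable at both ends, gives no direction for this change, and the two values shown both rest at the limit. The expected step that the limit leaves unreadable from compound 2 to compound 3 is therefore little more than a placeholder. Compound 3 is estimated at 80 ug/mL in this assay, with a range from 25 ug/mL to 250 ug/mL, and most likely again reported only as a limit.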

Compound 3, concentration for 50% growth inhibition: 35.2 ug/mL
Estimate against measurement, compound 3: 2.3-fold (0.36 log units) above; the range from low to high includes it.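

In this assay, among the compounds shown here, compound 3 is the only one of the three compounds with a number rather than a limit, so a change at this saturated chain carbon can give a readable value. Aminoamino in place of chloro gives an at least 1.4-fold lower number from compound 2 to compound 3 (0.15 log units; that floor lies within the scatter), and (aminoamino)methyl in place of 2-fluorophenyl gives an at least 1.4-fold lower number from compound 1 to compound 3 (0.15 log units; that floor lies within the scatter); each is only a floor, so the true gap may be larger, but neither floor alone shows a real difference. The step between compound 1 and compound 2 still cannot be read, because both rest at a limit of the assay: the limit of > 50 ug/mL in this assay, at which 2 of the 3 values shown sit.

On these data alone, how far compound 1 and compound 2 truly lie from compound 3 remains open. So does whether a plain amine or a hydroxyl on the same chain carbon, or a longer chain carrying aminoamino, would also give a number.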